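Adding a Second Chloro Across Two Related Cores

This account rests on a few compounds, and the source may have more. Where it says the series, first, only, none or still open, it means among the compounds named here.

Three compounds were assessed in a functional assay on KM12 cells (Homo sapiens) for cytotoxicity, read by sulforhodamine B assay, with a stated time of 48 h; a lower number here means a stronger inhibitor of growth, a higher number a weaker inhibitor of growth. Compound 1 `ClCc1ccc(Cn2cnc3c(Cl)ncnc32)cc1` gave 2140 nM, compound 2 `ClCc1ccccc1Cn1cnc2ncnc(Cl)c21` gave 3630 nM, and compound 3 `ClCc1ccc(Cn2cnc3c(Cl)nc(Cl)nc32)cc1` gave 1820 nM. Compound 3 arose from compound 1 by chloro in place of hydrogen on an aromatic carbon, which produced a 1.2-fold lower number from compound 1 to compound 3 (0.07 log units; within the scatter). Compound 2 and compound 1 are built from the same atoms joined differently; the difference between the two cores is not broken down here. The values of compound 2 and compound 1 lie within the scatter of one another, as do those of compound 2 and compound 3. Compound 4 `ClCc1ccccc1Cn1cnc2nc(Cl)nc(Cl)c21` has not yet been measured; it arises from compound 2 by chloro in place of hydrogen on an aromatic carbon, the same change as that from compound 1 to compound 3. The expected step is a 1.2-fold lower number from compound 2 to compound 4 (0.08 log units; within the scatter), because a 1.2-fold lower number from compound 1 to compound 3 (0.07 log units; within the scatter) stayed within the scatter. Compound 4 is accordingly estimated at 3000 nM, with a likely range from 1500 nM to 7000 nM.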

Compound 4, concentration for 50% growth inhibition: 11700 nM
For compound 4 the middle estimate is 3.9-fold (0.59 log units) below the measured one, and the stated range ends below it.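

In this assay, chloro in place of hydrogen on the aromatic carbon between two ring nitrogen atoms did not carry over from one core to the other: the same change on two cores in this assay, a 1.2-fold lower number (0.07 log units; within the scatter) from compound 1 to compound 3 and a 3.2-fold higher number (0.51 log units; beyond the scatter) from compound 2 to compound 4, 3.8-fold (0.58 log units) apart, beyond the scatter of two such steps. The change gave a 3.2-fold higher number from compound 2 to compound 4 (0.51 log units; beyond the scatter), a modest weakening of growth inhibition, while the same change on the other core stayed within the scatter. With a single pair on each core, this shows that the size of the step depended on the core here, but it does not show why, or what the change would do on any further core.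

As far as these compounds go, whether an amine or a methoxy group on that same carbon would follow chloro on either core remains open.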